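The source may hold more compounds than are shown below. What is called first, only, known or untested is meant among the compounds shown, and "the series" means these compounds.

Measured so far:
Compound 1, `C=C1CC[C@@H]2[C@](C)(COC(C)=O)[C@H](OC(C)=O)CC[C@@]2(C)[C@H]1CC(Nc1ccc(S(=O)(=O)Nc2nccc(C)n2)cc1)C1=CCOC1=O`: 4180 nM
Compound 2, `C=C1CC[C@@H]2[C@](C)(COC(C)=O)[C@H](OC(C)=O)CC[C@@]2(C)[C@H]1CC(Nc1ccc(S(=O)(=O)Nc2nccs2)cc1)C1=CCOC1=O`: 4740 nM

In a functional assay on RXF 393 cells (Homo sapiens) for inhibition, read by sulforhodamine B assay, with a stated time of 48 h (on this read-out higher numbers stand for weaker inhibition of growth and lower numbers for stronger inhibition of growth), compound 1 gives 4180 nM, the lowest of the two numbers. Compound 2 gives 4740 nM, and the step of a 1.1-fold higher number from compound 1 to compound 2 (0.05 log units; within the scatter) lies within the scatter, so the two values cannot be ranked. Compound 3, `C=C1CC[C@@H]2[C@](C)(COC(C)=O)[C@H](OC(C)=O)CC[C@@]2(C)[C@H]1CC(Nc1ccc(S(=O)(=O)Nc2ncccn2)cc1)C1=CCOC1=O`, differs from compound 1 by hydrogen in place of methyl on an aromatic carbon. Among the compounds with values here, the one measured step, a 1.1-fold higher number from compound 1 to compound 2 (0.05 log units; within the scatter), exchanges the whole ring on the sulfonamide nitrogen and left the number essentially unchanged; no measured step removes a methyl from an aromatic carbon of this ring, so there is no direct precedent. Given that the larger exchange at the same position produced nothing beyond the scatter, the smaller change here is expected to produce none beyond the scatter either. Compound 3 is therefore estimated to give 4400 nM, with a range from 2200 nM to 8800 nM. The expected step is a 1.1-fold higher number from compound 1 to compound 3 (0.02 log units; within the scatter).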

Compound 3, concentration for total growth inhibition: 3580 nM
For compound 3 the middle estimate is 1.2-fold (0.09 log units) above the measured one; the range from low to high includes it.
By their numbers in this assay, from the lowest: compounds 3, 1 and 2 (each within the scatter of the next).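

In this assay, hydrogen in place of methyl on the aromatic carbon gives a 1.2-fold lower number from compound 1 to compound 3 (0.07 log units; within the scatter) and so shows that this methyl can be removed without a change that can be read here. Pyrimidin-2-yl in place of 1,3-thiazol-2-yl on the sulfonamide nitrogen gives a 1.3-fold lower number from compound 2 to compound 3 (0.12 log units; within the scatter) and adds a second exchange at this position that stays within the scatter, so none of the three rings on that nitrogen can be ranked against another. Nothing available explains why these exchanges leave the numbers so close.

Still open, on these data alone, is whether a larger group on the same ring carbon, such as a methoxy group, an amine or a longer alkyl chain, would move the number beyond the scatter. Also open, as far as these compounds go, is what a carboxylic acid on this ring would do.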